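Aryl exchange on the chain carbon of the guanidine series

A few compounds are considered here, and "the series" means these few. Any claim that something is new, unique, unknown or untested is made for them only; others in the source may bear on it.

compound 1 `N=C(NCCCc1c[nH]cn1)NCCC(c1ccc(Br)cc1)c1ccccn1`: 1
compound 2 `N=C(NCCCc1c[nH]cn1)NCCC(c1ccc(Cl)c(Cl)c1)c1ccccn1`: 1

In a functional assay on cardiac atrium for agonist activity at histamine H2 receptor (Cavia porcellus) (on this read-out higher numbers stand for larger maximal responses and lower numbers for smaller maximal responses), compound 1 gives 1 and compound 2 gives 1. The step of no change at the digits printed from compound 1 to compound 2 (within the scatter) stays within the scatter, so compound 2 stands level with compound 1. Compound 3 `N=C(NCCCc1c[nH]cn1)NCCC(c1ccccc1)c1ccc(Cl)c(Cl)c1` differs from compound 2 by phenyl in place of pyridin-2-yl on a saturated chain carbon bound to an aromatic carbon and a saturated chain carbon. Among the compounds with values here, no measured step covers this exchange; the only step at hand, no change at the digits printed from compound 1 to compound 2 (within the scatter), altered the group at the same place without moving the read-out. A step no larger than the scatter is therefore expected, a number 0.050 lower from compound 2 to compound 3 (within the scatter). Compound 3 is estimated at 0.95, with a range from 0.75 to 1.05.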

Compound 3, intrinsic activity: the largest response reached, as a fraction of the reference agonist's: 1
For compound 3 the middle estimate is 0.050 below the measured one; the measured number falls inside the stated range.
By their numbers in this assay, from the lowest: compounds 1, 2 and 3 (each within the scatter of the next).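

Phenyl in place of pyridin-2-yl gives no change at the digits printed from compound 2 to compound 3 (within the scatter) in this assay, so on this saturated chain carbon the ring nitrogen and its hydrogen-bond acceptor can go without the read-out leaving the scatter. The earlier step exchanged only the halogenated phenyl group; this one exchanges the other aromatic group on that carbon. No evidence at hand accounts for this outcome. Open, going by these compounds, is whether a non-aromatic group such as cyclohexyl on this carbon, or an amine on the phenyl ring, would keep the maximal response at this level.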